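Adding a methyl to the anilino ring of a thiophene acid

The source may hold more compounds than are shown below. What is called first, only, known or untested is meant among the compounds shown, and "the series" means these compounds.

Going by the values given here, compound 2 `COc1ccc(C(=O)c2sc(Nc3ccccc3)c(C(=O)O)c2C)cc1` is the only compound of this small set with a number attached to it: in a functional assay, with a stated time of 150 min, tested at 10 ug/mL (on this read-out higher numbers stand for a stronger effect at the one concentration tested and lower numbers for a weaker effect), compound 2 gives 24.7%. Its companion compound 1 `COC(=O)c1c(Nc2ccc(C)cc2)sc(C(=O)c2ccc(OC)cc2)c1C`, which carries a methyl ester in place of the free acid and a 4-methylphenyl on the amino group, was reported in this assay only as "not active" (no number reported), without any number, so the two cannot be set against each other in figures.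

Compound 3 `COc1ccc(C(=O)c2sc(Nc3ccc(C)cc3)c(C(=O)O)c2C)cc1` has not yet been measured in this assay. It differs from compound 2 by a single change: methyl in place of hydrogen on an aromatic carbon. Among the compounds with values here, nothing among the measured compounds shows how this change alone acts on the read-out, since compound 1 differs from compound 3 in the ester as well.

With no guidance from a comparable pair, the step in this assay that is expected for compound 3 is a number 2.7 percentage points lower from compound 2 to compound 3 (within the scatter), that is, none beyond the usual scatter. Compound 3 is therefore estimated at 22%, with a range from 5% to 40%.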

Compound 3, a percentage reported as activity, at one concentration (the size of the read-out at that concentration, not a potency): "not active" (no number reported)
Compound 3 has no reported number here; the estimate stays without a comparison.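

In this assay, going by these compounds alone, compound 3 is recorded as "not active" (no number reported) and carries no number, so no step from compound 2 can be read. The compounds shown leave open what size of change, if any, the methyl on the anilino ring alone produces on this read-out. No evidence is available that bears on this result.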